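Bridged nucleosides and a combined substitution

The compounds below may be only part of what the source reports. "The series", "measured", "known", "first", "only" and "open" are said of these compounds alone.

Measured compounds:
- compound 1, `Nc1ncnc2c1ncn2[C@@H]1O[C@@]2(CO)CN[C@@H]1[C@@H]2O`: > 100000 nM
- compound 2, `CNC(=O)[C@@]12CN[C@@H]([C@H](n3cnc4c(N)ncnc43)O1)[C@@H]2O`: > 100000 nM
- compound 3, `OC[C@@]12CN[C@@H]([C@H](n3cnc4c(NCc5cccc(I)c5)ncnc43)O1)[C@@H]2O`: > 100000 nM

In a functional assay for agonist activity at adenosine receptor A3 (Homo sapiens), with a stated time of 30 min (on this read-out higher numbers stand for an effect only at larger amounts of compound and lower numbers for an effect already at smaller amounts), compound 1 reaches only the limit of the assay, > 100000 nM. In this assay compound 2 likewise reaches only a limit, > 100000 nM. For compound 3 this assay also gives only a limit, > 100000 nM, so no number places compound 3 among the others; all three values sit at one limit, (the limit of > 100000 nM in this assay, at which 3 of the 3 values shown sit).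

Compound 4, `CNC(=O)[C@@]12CN[C@@H]([C@H](n3cnc4c(NCc5cccc(I)c5)ncnc43)O1)[C@@H]2O`, has not yet been measured in this assay. It differs from compound 3 by methylcarbamoyl in place of hydroxymethyl on a saturated ring carbon. Among the measured compounds shown here, the change that bears on it is the one from compound 1 to compound 2, a step that the two limits leave unreadable from compound 1 to compound 2, and the path to compound 3 itself runs over a step that the two limits leave unreadable from compound 1 to compound 3; neither step has a readable size. The expectation for the step from compound 3 to compound 4 therefore rests on limits alone and is estimated as an at least 2.0-fold lower number from compound 3 to compound 4 (0.30 log units; that floor lies within the scatter). For compound 4 an estimate of 50000 nM, between 5000 nM and 100000 nM, is expected, with a real chance that only a limit is reported again.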

Compound 4, half-maximal effective concentration: > 100000 nM
Compound 4: a limit, no number; the forecaster's own chance of this, stated with the estimate: 60%; at least 2.0-fold (0.30 log units) between middle value and limit.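

In this assay compound 4 gives > 100000 nM, again only a limit, so its steps from compound 3 and from compound 2 cannot be read. The compounds shown leave open what methylcarbamoyl or 3-iodobenzyl does to this read-out, for no number exists to compare: the limit of > 100000 nM in this assay, at which 4 of the 4 values shown sit.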